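Swapping the outer ring: compound 1 to compound 4

The compounds below may be only part of what the source reports. "The series", "measured", "known", "first", "only" and "open" are said of these compounds alone.

Of the compounds shown here, three sharing one core have been measured in a physicochemical assay for lipophilicity, read by HPLC, at pH 7.5; on this read-out higher numbers stand for higher lipophilicity and lower numbers for lower lipophilicity. Compound 1 `CC[C@@H](Nc1c(C#N)c(-c2ccc(-c3ncccc3C)cc2)nc2cnccc12)C(N)=O` gives 2, the lowest of the three numbers. Compound 2 `CCOc1ccccc1-c1ccc(-c2nc3cnccc3c(C[C@H](C)C(=O)O)c2C#N)cc1` gives 2.2, which lies within the scatter of compound 1, so the two cannot be told apart. Compound 3 `CCOc1ccccc1-c1ccc(-c2nc3cnccc3c(NC(C(N)=O)C3CC3)c2C#N)cc1` gives 3, beyond the scatter above compound 1. Among the measured compounds shown here, the only single-point step among the measured compounds is a number 0.80 log units higher from compound 2 to compound 3 (beyond the scatter), and that change sits at a different place on the core from the one considered here, so no measured step bears directly on it.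

Compound 4 `CC[C@@H](Nc1c(C#N)c(-c2ccc(-c3cccc(CO)c3)cc2)nc2cnccc12)C(N)=O` differs from compound 1 as follows: 3-(hydroxymethyl)phenyl in place of 3-methylpyridin-2-yl on an aromatic carbon. A ring with one nitrogen leaves and a ring of carbon only enters, while a hydroxymethyl group, carrying a hydrogen-bond donor, arrives. In the absence of a guiding step, the expected change is no change at the digits printed from compound 1 to compound 4 (within the scatter), that is none beyond the scatter. Compound 4 is therefore estimated at 2, expected to fall between 1.4 and 2.6.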

Compound 4, distribution coefficient: 2
Compound 4: the middle estimate sits on the measured number at the digits printed; measured number inside the range.
By their numbers in this assay, from the lowest: compounds 1, 4 and 2 (each within the scatter of the next); then compound 3.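

In this assay, among the compounds shown here, this is the first measured change to the outer ring, which sits para to a large group, and the result is no change at the digits printed from compound 1 to compound 4 (within the scatter). So on this read-out, 3-(hydroxymethyl)phenyl cannot be told apart from 3-methylpyridin-2-yl, even though the change removes the ring nitrogen and adds a hydrogen-bond donor. No separate measurement is available to explain why these two groups read alike.

The ring and its side group change together, so a single step cannot show what each change does alone; a plain phenyl ring or a 3-methylphenyl group would help to separate them. On these data alone, it also remains open whether a carboxylic acid or an amine in place of the hydroxymethyl group would shift the number beyond the scatter.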